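The source may report more compounds than this note shows. Statements on the series, on what has been measured and on what is new or still open speak of the compounds shown alone.

Measured so far in a functional assay on COLO 320 cells (Homo sapiens) for antiproliferative activity, read by WST assay, with a stated time of 72 h; on this read-out lower numbers stand for stronger inhibition and higher numbers for weaker inhibition:
compound 1, `Fc1ccc2[nH]c(-c3nc(-c4ccc(Cl)cc4)no3)cc2c1`: compound 1 reaches only the assay limit, > 50000 nM.
compound 2, `O=[N+]([O-])c1ccc2[nH]c(-c3nc(-c4ccc(Cl)cc4)no3)cc2c1`: compound 2 gives 7700 nM.

For the measured compounds named here, compound 2 stands as the only number obtained in this assay; the remaining value is a limit rather than a number, (the limit of > 50000 nM in this assay, at which 1 of the 2 values shown sits). Going by the values given here, the single step measured, an at least 6.4-fold lower number from compound 1 to compound 2 (0.81 log units; beyond the scatter), shows that nitro in place of fluoro on an aromatic carbon lowered the number beyond the scatter, with the true size unknown because compound 1 sits at the limit.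

The next compound, compound 3, `Clc1ccc(-c2noc(-c3cc4cc(Cl)ccc4[nH]3)n2)cc1`, differs from compound 2 by chloro in place of nitro on an aromatic carbon. This change removes the nitro whose arrival gave the only clear improvement and returns a halogen to the same position, so the step measured bears on it in reverse. A rise in the number is therefore expected, possibly back toward the limit, though chloro need not behave as fluoro did. Compound 3 is estimated at 25000 nM, within 8000 nM to 50000 nM. The expected step is a 3.2-fold higher number from compound 2 to compound 3 (0.51 log units; beyond the scatter).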

Compound 3, half-maximal inhibitory concentration: 25000 nM
Compound 3: the middle estimate sits on the measured number at the digits printed; the range from low to high includes it.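

In this assay, the nitro of compound 2 now has the lowest number against two different halogens at this position on the six-membered aromatic ring, not against fluoro alone: chloro in place of nitro gives a 3.2-fold higher number from compound 2 to compound 3 (0.51 log units; beyond the scatter). Compound 3 also gives a measured number with a halogen at this position, so a halogen here does not always end at the limit, yet chloro in place of fluoro gives an at least 2.0-fold lower number from compound 1 to compound 3 (0.30 log units; that floor lies within the scatter), and no order between chloro and fluoro can be claimed from that floor. The true size of that step stays unknown because compound 1 gives a limit and not a number: the limit of > 50000 nM in this assay, at which 1 of the 3 values shown sits.

The three compounds do not show whether nitro is the best choice at this position or only better than these two halogens, and an amine, a methoxy group or a carboxylic acid there would test this. From the compounds shown here alone, whether the same order of nitro over chloro holds when another part of the shared core changes also stays open.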